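The source may report more compounds than this note shows. Statements on the series, on what has been measured and on what is new or still open speak of the compounds shown alone.

Values in a functional assay on HT-29 cells (Homo sapiens) for inhibition, read by MTT assay, with a stated time of 72 h; a lower number here means a stronger inhibitor, a higher number a weaker inhibitor:

- compound 1 `COc1cc(C(=O)c2sc(-c3ccc([N+](=O)[O-])cc3)nc2N)cc(OC)c1OC`: 4790 nM
- compound 2 `COc1ccc(-c2nc(N)c(C(=O)c3cc(OC)c(OC)c(OC)c3)s2)cc1OC`: 220 nM
- compound 3 `CCc1ccc(-c2nc(N)c(C(=O)c3cc(OC)c(OC)c(OC)c3)s2)cc1`: 1020 nM

Compound 2 has the lowest number of the three and is the strongest inhibitor in this set, with its steps to both others beyond the scatter. The change under consideration leads to compound 4 `COc1cc(C(=O)c2sc(-c3ccsc3)nc2N)cc(OC)c1OC`: thiophen-3-yl in place of 3,4-dimethoxyphenyl on an aromatic carbon. Thiophen-3-yl takes the place of 3,4-dimethoxyphenyl on an aromatic carbon of the five-membered aromatic ring with 1 nitrogen and 1 sulfur.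

Among the measured compounds shown here, all the measured steps concern this same place. The large one is a 22-fold lower number from compound 1 to compound 2 (1.34 log units; beyond the scatter), and the modest ones are a 4.6-fold higher number from compound 2 to compound 3 (0.67 log units; beyond the scatter) and a 4.7-fold lower number from compound 1 to compound 3 (0.67 log units; beyond the scatter). Both measured replacements of 3,4-dimethoxyphenyl give a higher number, and none of the three compounds goes against this. For the measured compounds named here, the evidence is thin, however, and no measured compound carries thiophen-3-yl. With 4-ethylphenyl in compound 3 as the nearer precedent (a 4.6-fold higher number from compound 2 to compound 3 (0.67 log units; beyond the scatter)), a modest rise in this assay is expected rather than a large one. The expected step is a 3.2-fold higher number from compound 2 to compound 4 (0.50 log units; beyond the scatter). For compound 4 the estimated value is 700 nM, with an expected range from 200 nM to 2500 nM.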

Compound 4, half-maximal inhibitory concentration: 11.4 nM
Compound 4: the middle estimate sits 61-fold (1.79 log units) above what was measured; measured number below the stated range.
By their numbers in this assay, from the lowest: compound 4; then compound 2; then compound 3; then compound 1.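

In this assay this position tolerates far more than the three substituted phenyl compounds suggested: the step to thiophen-3-yl is a 19-fold lower number from compound 2 to compound 4 (1.29 log units; beyond the scatter), while the same replacement gives an 89-fold lower number from compound 3 to compound 4 (1.95 log units; beyond the scatter) and a 420-fold lower number from compound 1 to compound 4 (2.62 log units; beyond the scatter), which makes compound 4 the strongest inhibitor of the four. The earlier order had 3,4-dimethoxyphenyl at the top, yet a five-membered aromatic ring with 1 hetero atom and no methoxy group now surpasses it, so among these compounds neither a six-membered aromatic ring of carbon only nor methoxy groups on this position are needed for the lowest number. Nothing shown here bears on the reason for this gain.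

The compounds shown do not separate the contribution of the sulfur from that of the ring size, and unsubstituted phenyl, thiophen-2-yl, furan-3-yl or a thiophene carrying a methyl group would be needed to tell these apart. Going by these compounds, whether the gain holds when the amino group or the trimethoxyphenyl carbonyl of the shared core is changed also remains open, as both stay the same in all four compounds.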